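Chloro Replaces Trifluoromethyl: From Compound 2 to Compound 3

The source may hold more compounds than are shown below. What is called first, only, known or untested is meant among the compounds shown, and "the series" means these compounds.

Compound 1 `COc1cc2cc(Oc3ccc(NC(=O)Nc4cccc(C(F)(F)F)c4)cc3)c(C)nc2cc1OC` and compound 2 `COc1cc2cc(Oc3ccc(NC(=O)Nc4ccc(Cl)c(C(F)(F)F)c4)cc3)c(C)nc2cc1OC` share the same core and differ in a single place. In a functional assay on SW-620 cells (Homo sapiens) for inhibition, read by sulforhodamine B assay, with a stated time of 48 h, tested at 10 uM (on this read-out higher numbers stand for a weaker effect at the one concentration tested and lower numbers for a stronger effect), compound 1 gives 17.5%, and compound 2 gives 7.51%. The step of a number 10 percentage points lower from compound 1 to compound 2 (within the scatter) lies within the scatter, so compound 2 holds the lower of the two numbers without separating itself from compound 1. Compound 3 `COc1cc2cc(Oc3ccc(NC(=O)Nc4ccc(Cl)c(Cl)c4)cc3)c(C)nc2cc1OC` has not yet been measured; it differs from compound 2 by chloro in place of trifluoromethyl on an aromatic carbon. Going by the values given here, no measured step bears directly on this exchange, and the one step seen, a number 10 percentage points lower from compound 1 to compound 2 (within the scatter), stayed within the scatter. With nothing pointing to a larger effect, compound 3 is expected to remain close to its neighbour in this assay, with a step of a number 4.5 percentage points higher from compound 2 to compound 3 (within the scatter). Compound 3 is therefore estimated at 12%, within a range from 3% to 30%.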

Compound 3, a percentage reported as activity, at one concentration (the size of the read-out at that concentration, not a potency): 23.4%
Estimate against measurement, compound 3: 11.4 percentage points below; measured number inside the range.
By their numbers in this assay, from the lowest: compounds 2, 1 and 3 (each within the scatter of the next, the first and the last beyond it).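

In this assay, going by these compounds alone, putting chloro in place of trifluoromethyl on this aromatic carbon gives a number 15.9 percentage points higher from compound 2 to compound 3 (beyond the scatter) and is the first step here to lie beyond the scatter, so this position does respond to a change of group, if only modestly. The wider change, 3,4-dichlorophenyl in place of 3-(trifluoromethyl)phenyl on the amide-type nitrogen, gives a number 5.9 percentage points higher from compound 1 to compound 3 (within the scatter) and stays within the scatter, so the separation holds only between compound 2 and compound 3. No measurement at hand accounts for the step.

The compounds shown leave open how a methyl, a methoxy or an amine on this same aromatic carbon would read in this assay and where it would fall among these three. They also leave open whether this exchange would give a step of similar size without the chloro group that lies ortho to this position.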